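The source may report more compounds than this note shows. Statements on the series, on what has been measured and on what is new or still open speak of the compounds shown alone.

Working notes on the series. In a functional assay with Cavia porcellus as the target (on this read-out higher numbers stand for weaker binding and lower numbers for tighter binding), compound 1 (`CCN(C)CC#CCN1C(=O)CCC1C`) gives 2500 nM and compound 2 (`CCN(CC)CC#CCN1C(=O)CCC1C`) gives 2100 nM. Going by the values given here, these two numbers lie within the scatter of each other, so compound 2 is not separated from the only other measured compound.

The next compound is compound 3 (`CC1CCC(=O)N1CC#CCN(C)C`), which differs from compound 2 as follows: dimethylamino in place of diethylamino on a saturated chain carbon bound to a triple-bonded carbon. This places dimethylamino in place of diethylamino on a saturated chain carbon bound to a triple-bonded carbon.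

Among the compounds with values here, one measured step bears on this change. Methyl in place of hydrogen on a saturated chain carbon bound to an amine nitrogen gave a 1.2-fold lower number from compound 1 to compound 2 (0.08 log units; within the scatter). The change to compound 3 reverses that kind of replacement and goes further, so this step covers only part of it. With so little evidence, no shift beyond the scatter is expected in this assay, and any small drift is expected toward a higher number. The expected change is a 1.3-fold higher number from compound 2 to compound 3 (0.12 log units; within the scatter). For compound 3 the estimated value is 2800 nM, with an expected range of 1100 nM to 6500 nM.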

Compound 3, dissociation constant: 11800 nM
Compound 3: the middle estimate sits 4.2-fold (0.62 log units) below what was measured; measured number outside the range, above it.
By their numbers in this assay, from the lowest: compounds 2 and 1 (each within the scatter of the next); then compound 3.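

In this assay, the amine end of the series proves sensitive to change: dimethylamino in place of diethylamino gives a 5.6-fold higher number from compound 2 to compound 3 (0.75 log units; beyond the scatter), and hydrogen in place of methyl on a saturated chain carbon bound to an amine nitrogen gives a 4.7-fold higher number from compound 1 to compound 3 (0.67 log units; beyond the scatter). The same kind of replacement, taken one step further along this chain, therefore does what the earlier step did not, since a 1.2-fold lower number from compound 1 to compound 2 (0.08 log units; within the scatter) stayed within the scatter, so among these three compounds the size of the shift depends on which amine it starts from, with compound 1 and compound 2 together standing apart from compound 3. Nothing available explains why the shift appears only at dimethylamino.

Three amines on one shared core cannot show whether the number keeps its level with a longer chain such as dipropylamino or with a ring amine such as pyrrolidine. From the compounds shown here alone, it also remains open whether the same replacement gives a shift of this size when the rest of the core is changed.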